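Working notes: nitrogen substitution in a small biaryl series

The source may report more compounds than this note shows. Statements on the series, on what has been measured and on what is new or still open speak of the compounds shown alone.

Measured so far:
Compound 1, `COc1ccc(-c2ccc3c(c2)C(=O)C(=O)N3)cc1`, in a functional assay on HepG2 cells (Homo sapiens) for antiproliferative activity, read by MTT assay, with a stated time of 48 h; a lower number here means a stronger inhibitor, a higher number a weaker inhibitor: 960 nM
Compound 2, `O=C1Nc2ccc(-c3ccc(C(F)(F)F)cc3)cc2C1=O`, in this assay: 5430 nM
Compound 3, `CCN1C(=O)C(=O)c2cc(-c3ccc(OC)cc3)ccc21`, in this assay: 4470 nM

Compound 2 gives the highest of the three numbers. Its nearest neighbour is compound 3, and the two lie within the scatter of each other, so no order between them can be read. Compound 1 stands furthest away, and the step of a 5.7-fold higher number from compound 1 to compound 2 (0.75 log units; beyond the scatter) is beyond the scatter.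

Compound 4, `COc1ccc(CN2C(=O)C(=O)c3cc(-c4ccc(C(F)(F)F)cc4)ccc32)cc1`, has not yet been measured. Relative to compound 2 it differs in one place: 4-methoxybenzyl in place of hydrogen on an amide-type nitrogen in a ring. Of the measured steps only one touches the same position, a 4.7-fold higher number from compound 1 to compound 3 (0.67 log units; beyond the scatter), ethyl in place of hydrogen on an amide-type nitrogen in a ring. The other step, a 5.7-fold higher number from compound 1 to compound 2 (0.75 log units; beyond the scatter), concerns the aromatic carbon and does not bear on the change to compound 4; compound 2 already carries the trifluoromethyl that compound 4 keeps. Among the measured compounds shown here, no measured compound carries 4-methoxybenzyl on that nitrogen; ethyl is the only substituent seen there, so the size of the step for a 4-methoxybenzyl rests on that single comparison.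

In this assay a step in the same direction as the ethyl step, and of comparable size, is expected: a 3.3-fold higher number from compound 2 to compound 4 (0.52 log units; beyond the scatter). Compound 4 is therefore estimated at 18000 nM, with a range from 5000 nM to 60000 nM. Because compound 2 already gives 5430 nM, the expected number for compound 4 lies towards the top of the tested range.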

Compound 4, half-maximal inhibitory concentration: 820 nM
The estimate for compound 4 lay 22-fold (1.34 log units) above the measured number, and the stated range ends above it.
By their numbers in this assay, from the lowest: compounds 4 and 1 (each within the scatter of the next); then compounds 3 and 2 (each within the scatter of the next).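

In this assay, a substituent on the amide-type nitrogen in a ring does not have to raise the number: 4-methoxybenzyl in place of hydrogen gives a 6.6-fold lower number from compound 2 to compound 4 (0.82 log units; beyond the scatter), whereas ethyl in place of hydrogen gave a 4.7-fold higher number from compound 1 to compound 3 (0.67 log units; beyond the scatter). The two steps run in opposite directions, both beyond the scatter, so this nitrogen tolerates substitution with at least one group, and the direction of the step cannot be carried over from one substituent to another. No measurement on hand accounts for this difference between ethyl and 4-methoxybenzyl.

On these data alone, the two steps start from different compounds, one carrying methoxy and the other trifluoromethyl on the aromatic carbon, so it remains open whether the lower number belongs to 4-methoxybenzyl alone or depends on the trifluoromethyl that compound 4 keeps. Also open, as far as these compounds go, is which part of the 4-methoxybenzyl group matters, and how the series would respond on this nitrogen to a plain benzyl, a longer alkyl chain or a chain ending in an amine.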